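Ethoxy added to the sulfonamide core of compound 1

A few compounds are considered here, and "the series" means these few. Any claim that something is new, unique, unknown or untested is made for them only; others in the source may bear on it.

Compound 1 `COc1ccc(S(=O)(=O)Nc2cccc3[nH]nc(Cl)c23)cc1` gives the lowest of the two numbers in a functional assay on A2780 cells (Homo sapiens) for cytotoxicity, read by MTT assay, with a stated time of 72 h (a higher number here means a weaker inhibitor, a lower number a stronger inhibitor), at 860 nM; compound 2 `CCOc1ccc(NS(=O)(=O)c2ccc(C)cc2)c2c(Br)n[nH]c12` stands apart in this assay with 10500 nM. Compound 3 `CCOc1ccc(NS(=O)(=O)c2ccc(OC)cc2)c2c(Cl)n[nH]c12` differs from compound 1 by ethoxy in place of hydrogen on an aromatic carbon. For the measured compounds named here, no measured pair traces this change alone, so its size is uncertain, but a moderate rise beyond the scatter is expected, because compound 2, which also carries an ethoxy, gives 10500 nM. Compound 3 is therefore estimated at 3000 nM, within 1000 nM to 12000 nM, a step of a 3.5-fold higher number from compound 1 to compound 3 (0.54 log units; beyond the scatter).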

Compound 3, half-maximal inhibitory concentration: 1230 nM
Compound 3: middle estimate off by 2.4-fold (0.39 log units), on the high side; low and high end bracket the measured number.
By their numbers in this assay, from the lowest: compounds 1 and 3 (each within the scatter of the next); then compound 2.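

In this assay, ethoxy in place of hydrogen on an aromatic carbon, para to a large group, gives a 1.4-fold higher number from compound 1 to compound 3 (0.16 log units; within the scatter), so this position accepts the ethoxy group without a change that can be told from the scatter. Compound 2 could not show this, as it differs from compound 1 in more than one place. Nothing measured here explains the result.

From the compounds shown here alone, whether a longer chain, an amine or a carboxylic acid would be accepted at this position stays open.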